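The source may hold more compounds than are shown below. What is called first, only, known or untested is meant among the compounds shown, and "the series" means these compounds.

In an ADME assay on HEK-293T cells (Homo sapiens) for cytotoxicity, read by CCK-8 assay, with a stated time of 24 h (a lower number here means that less compound is tolerated, a higher number that more compound is tolerated), the measured compounds are:
- Compound 1 `O=C(CSc1c[nH]c2ccccc12)NCc1ccc(C(F)(F)F)cc1` gives > 100000 nM as a limit
- Compound 2 `Cn1cc(SCC(=O)NCc2ccc(C(F)(F)F)cc2)c2ccccc21` gives > 100000 nM as a limit
- Compound 3 `COc1ccccc1CNC(=O)CSc1c[nH]c2c(-c3ccccc3)cccc12` gives a number (95500 nM)

Compound 2 therefore has no number in this assay and stands only at a limit. The same is true of compound 1, so the set sits largely at one mark (the limit of > 100000 nM in this assay, at which 2 of the 3 values shown sit). Going by the values given here, compound 3 is the only compound with a true number.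

Compound 4 `Cn1cc(SCC(=O)NCc2ccccc2)c2ccccc21` has not been measured. It differs from compound 2 by hydrogen in place of trifluoromethyl on an aromatic carbon and so carries hydrogen in place of trifluoromethyl on an aromatic carbon. Among the compounds with values here, no measured step covers this change. Within the data shown here, the only step available, a step that the two limits leave unreadable from compound 1 to compound 2, is a methyl in place of hydrogen on an aromatic nitrogen, and its size cannot be read. Compound 3 also lacks trifluoromethyl and gives a number (95500 nM), although it differs from compound 2 in several places.

No step beyond the scatter is expected, in either direction, and a reading at the limit is the likely outcome. The expected step is a step that the limit leaves unreadable from compound 2 to compound 4 and remains an estimate. For compound 4 the estimated value is 130000 nM with an expected range from 70000 nM to 300000 nM (an expectation, not a measurement).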

Compound 4, half-maximal cytotoxic concentration: 95500 nM
Estimate against measurement, compound 4: 1.4-fold (0.13 log units) above; the range from low to high includes it.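

In this assay, going by these compounds alone, hydrogen in place of trifluoromethyl on an aromatic carbon, at a place para to a large group, gives the first step that can be read at all, an at least 1.0-fold lower number from compound 2 to compound 4 (0.01 log units; that floor lies within the scatter). Compound 2 stands at > 100000 nM, which is a limit and not a number. The step is therefore only a floor: it shows that the compound without trifluoromethyl has a true number close to that mark, but it does not show how far compound 2 lies past its limit, and the set gives little room to read more: the limit of > 100000 nM in this assay, at which 2 of the 4 values shown sit.

The compounds shown leave open whether the true gap for this change lies beyond the scatter, and whether the same change would give a like step on the core of compound 1, which carries hydrogen on the aromatic nitrogen and whose step to compound 2 cannot be read. They also leave open what other groups at this place, such as a methoxy group, a nitrile or an amine, would give in this assay.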